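A few compounds are considered here, and "the series" means these few. Any claim that something is new, unique, unknown or untested is made for them only; others in the source may bear on it.

Compound 3 `CC(Oc1ccccc1-c1ccc(O)cc1)C1=NCCN1` belongs to a small set of three compounds tested in a functional assay on CHO cells for agonist activity at Alpha-2B adrenergic receptor (Homo sapiens) (on this read-out lower numbers stand for smaller maximal responses and higher numbers for larger maximal responses), none of which returns a number. In this assay compound 3 gives < 0.3, which is a limit of the assay rather than a measured value. Compound 1 `CC(Oc1ccccc1-c1ccccc1[N+](=O)[O-])C1=NCCN1` gives < 0.3, also a limit. Compound 2 `CC(Oc1ccccc1-c1ccccc1)C1=NCCS1` gives < 0.3, again a limit. Going by the values given here, all three values share (the limit of < 0.3 in this assay, at which 3 of the 3 values shown sit), so no step between measured compounds can be drawn. Compound 4 `Cc1ccc(-c2ccccc2OC(C)C2=NCCN2)cc1` has not yet been measured; it differs from compound 3 by methyl in place of hydroxy on an aromatic carbon. With every neighbour at the limit, the expected step from compound 3 to compound 4 is a step that the limit leaves unreadable from compound 3 to compound 4, none beyond the scatter. Compound 4 is estimated at 0.2, within a range from 0.05 to 0.4.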

Compound 4, intrinsic activity: the largest response reached, as a fraction of the reference agonist's: < 0.3
Compound 4: only a limit was reported (the forecaster's own chance of this, stated with the estimate: 70%); the middle value does not contradict the limit.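

No step can be read between compound 3 and compound 4, because both values are limits: the limit of < 0.3 in this assay, at which 4 of the 4 values shown sit.

The compounds shown leave open which change to the shared core, if any, would give a readable maximal response in this assay.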